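Two Measured Sulfonamides and a Styryl Analogue Awaiting Assay

The compounds below may be only part of what the source reports. "The series", "measured", "known", "first", "only" and "open" are said of these compounds alone.

Measured so far:
compound 1, `NS(=O)(=O)c1cc(-c2nnc(CN3CCN(c4ccc(Cl)cc4)CC3)o2)c(Cl)cc1SCc1ccccc1`, 280000 nM
compound 2, `NC(=O)c1cn(Cc2nnc(-c3cc(S(N)(=O)=O)c(SCc4ccccc4)cc3Cl)o2)nn1`, 78000 nM

Both compounds were tested in a functional assay on MCF7 cells (Homo sapiens) for cytotoxicity, read by MTT assay, with a stated time of 72 h; on this read-out higher numbers stand for weaker inhibition and lower numbers for stronger inhibition. Compound 1 gives 280000 nM and compound 2 gives 78000 nM, so compound 2 has the lowest of the two numbers, and the gap to compound 1 lies beyond the scatter. Among the compounds with values here, no pair of these two differs in only one place, so no single step can be read from them.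

The next compound, compound 3, is `NS(=O)(=O)c1cc(-c2nnc(/C=C/c3cccc(Cl)c3)o2)c(Cl)cc1SCc1ccccc1`. It is derived from compound 2 by one change: 2-(3-chlorophenyl)ethenyl in place of (4-carbamoyl-1H-1,2,3-triazol-1-yl)methyl on an aromatic carbon. Within the data shown here, nothing in the measured pair tracks this exchange, so there is no step to anchor an expectation for the result in this assay. On the two values available, the estimate for compound 3 is held near compound 2, with the step of a 1.3-fold lower number from compound 2 to compound 3 (0.11 log units; within the scatter) expected to fall within the scatter or only modestly toward a lower number. Compound 3 is therefore expected to give 60000 nM, in the range 15000 nM to 200000 nM.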

Compound 3, half-maximal inhibitory concentration: 11000 nM
Beside the measured number, compound 3's estimate is 5.5-fold (0.74 log units) above it; the whole stated range lies above it.
By their numbers in this assay, from the lowest: compound 3; then compound 2; then compound 1.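

In this assay, within the data shown here, the aromatic carbon of the five-membered aromatic ring with 2 nitrogen and 1 oxygen turns out to be a place where a single exchange moves the read-out: putting 2-(3-chlorophenyl)ethenyl in place of (4-carbamoyl-1H-1,2,3-triazol-1-yl)methyl gives a 7.1-fold lower number from compound 2 to compound 3 (0.85 log units; beyond the scatter), the first step that can be read from one change. The two groups match in heavy-atom count, so that count alone does not separate them, but they differ in several other ways at once: the entering group brings a six-membered aromatic ring of carbon only and a chlorine, and it has no hydrogen-bond donors or acceptors, whereas the leaving group has both. No measurement here explains why the number falls at this position.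

The compounds shown leave open which of these differences carries the step, since the chlorine, the ethenyl link and the ring all change together. A plain 2-phenylethenyl group, or a saturated ethyl chain in place of the ethenyl link with the 3-chlorophenyl ring kept, would pull those parts apart.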